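Replacing the fluorophenyl group: expected cytotoxicity

A few compounds are considered here, and "the series" means these few. Any claim that something is new, unique, unknown or untested is made for them only; others in the source may bear on it.

Compound 1 `COc1cc2c(Oc3ccc(NC(=O)c4cc(-c5ccc(F)cc5)ccn4)cc3F)ccnc2cc1OCCCN1CCCCC1`, compound 2 `COc1cc2c(Oc3ccc(NC(=O)c4cc(-c5ccc(F)cc5)ccn4)cc3F)ccnc2cc1OCCCN1CCN(C)CC1` and compound 3 `COc1cc2c(Oc3ccc(NC(=O)c4cc(-c5ccc(F)cc5)ccn4)cc3F)ccnc2cc1OCCCN1CCCC1` differ only in the amine at the end of the chain. In a functional assay on NCI-H460 cells (Homo sapiens) for cytotoxicity, read by MTT assay, with a stated time of 72 h (a lower number here means a stronger inhibitor, a higher number a weaker inhibitor), compound 1 gives 250 nM, compound 2 gives 430 nM and compound 3 gives 370 nM. Of these three numbers that of compound 3 is the second highest; the steps to it are a 1.5-fold higher number from compound 1 to compound 3 (0.17 log units; within the scatter) and a 1.2-fold lower number from compound 2 to compound 3 (0.07 log units; within the scatter). Compound 4 `COc1ccc(-c2ccnc(C(=O)Nc3ccc(Oc4ccnc5cc(OCCCN6CCCC6)c(OC)cc45)c(F)c3)c2)c(OC)c1` is not yet measured; it differs from compound 3 by 2,4-dimethoxyphenyl in place of 4-fluorophenyl on an aromatic carbon. Going by the values given here, none of the measured steps, a 1.7-fold higher number from compound 1 to compound 2 (0.24 log units; within the scatter) included, touches this ring, so they carry little information on the change. With no step beyond the scatter anywhere in the set, compound 4 is expected to give 400 nM (range 130 nM to 1300 nM) in this assay. The expected step is a 1.1-fold higher number from compound 3 to compound 4 (0.03 log units; within the scatter), within the scatter but uncertain.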

Compound 4, half-maximal inhibitory concentration: 520 nM
For compound 4 the middle estimate is 1.3-fold (0.11 log units) below the measured one; the measured number falls inside the stated range.
By their numbers in this assay, from the lowest: compounds 1, 3, 2 and 4 (each within the scatter of the next, the first and the last beyond it).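

In this assay, going by these compounds alone, the first step at this ring, 2,4-dimethoxyphenyl in place of 4-fluorophenyl opposite the ring nitrogen, gives a 1.4-fold higher number from compound 3 to compound 4 (0.15 log units; within the scatter). The position therefore accepts a group of 10 heavy atoms with 2 hydrogen-bond acceptors in place of one of 7 heavy atoms with none, with no step beyond the scatter. Nothing measured accounts for the size of this step.

Open, on these data alone, is whether a plain phenyl or a phenyl carrying a single methoxy group or a carboxylic acid would stay within the scatter of compound 3. Also open, as far as these compounds go, is whether 2,4-dimethoxyphenyl behaves alike with piperidin-1-yl or 4-methylpiperazin-1-yl at the end of the chain.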